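A Methoxyphenyl Chalcone Expected to Stay at the Limit

The source may hold more compounds than are shown below. What is called first, only, known or untested is meant among the compounds shown, and "the series" means these compounds.

The chalcones of this study share the core of compound 1 `COc1cc(OC)c(OC)cc1/C=C/C(=O)c1ccc(OC)c2c1OC(C)(C)C=C2`. In a functional assay on K562 cells (Homo sapiens) for antiproliferative activity, read by MTT assay, with a stated time of 24 h (a higher number here means a weaker inhibitor, a lower number a stronger inhibitor), compound 1 gives only a limit of the assay, > 10000 nM. Compound 2 `COc1ccc(C(=O)/C=C/c2ccc(F)cc2)c2c1C=CC(C)(C)O2` carries a 4-fluorophenyl on the chain. In this assay compound 2 likewise reaches only a limit, > 10000 nM. Compound 3 `COc1ccc(C(=O)/C=C/c2ccccc2)c2c1C=CC(C)(C)O2` differs from compound 2 by hydrogen in place of fluoro on an aromatic carbon. In this assay compound 3 also stops at a limit, > 10000 nM. Within the data shown here, the step that the two limits leave unreadable from compound 2 to compound 3 therefore cannot be read, and the evidence the limit of > 10000 nM in this assay, at which 3 of the 3 values shown sit, shows that every value so far sits at one limit.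

Compound 4 `COc1ccccc1/C=C/C(=O)c1ccc(OC)c2c1OC(C)(C)C=C2` is not yet measured. It differs from compound 2 as follows: 2-methoxyphenyl in place of 4-fluorophenyl on a double-bonded chain carbon bound to a double-bonded chain carbon. No readable measured step bears on this change, since the only step shown, a step that the two limits leave unreadable from compound 2 to compound 3, is unreadable. Compound 4 is therefore expected to remain near the limit, with an estimate of 15000 nM. Its expected range runs from 4000 nM to 60000 nM. The step that the limit leaves unreadable from compound 2 to compound 4 that this estimate means is expected to be small, and the assay is likely to report again only a limit.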

Compound 4, half-maximal inhibitory concentration: > 10000 nM
Compound 4 ended at the assay's limit; the forecaster's own chance of this, stated with the estimate: 75%; the middle value lies beyond the limit too.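

Compound 4 joins compound 2 and compound 3 at a limit, so no step from either of them to compound 4 can be read: the limit of > 10000 nM in this assay, at which 4 of the 4 values shown sit.

The compounds shown leave open how 2-methoxyphenyl and 4-fluorophenyl compare in this assay, and whether any change on the shared core gives a value inside its range.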